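This account rests on a few compounds, and the source may have more. Where it says the series, first, only, none or still open, it means among the compounds named here.

In a functional assay on SK-OV-3 cells (Homo sapiens) for antiproliferative activity, read by MTT assay, with a stated time of 72 h (a higher number here means a weaker inhibitor, a lower number a stronger inhibitor), compound 1 (`CCNC(=O)CCc1cccc2c1B(O)OC2`) gives > 100000 nM, which is a limit of the assay and not a number. Compound 2 (`O=C(CCc1cccc2c1B(O)OC2)NC1CCCCC1`) also gives only a limit, > 100000 nM. Compound 3 (`O=C(CCc1cccc2c1B(O)OC2)Nc1ccccc1`) differs from compound 2 by phenyl in place of cyclohexyl on an amide-type nitrogen, with phenyl in place of cyclohexyl on an amide-type nitrogen. Within the data shown here, the one measured step that bears on this change, a step that the two limits leave unreadable from compound 1 to compound 2, offers no size to carry over. The evidence amounts to the limit of > 100000 nM in this assay, at which 2 of the 2 values shown sit. The expected change is therefore small and its direction uncertain, an estimated at least 1.2-fold lower number from compound 2 to compound 3 (0.09 log units; that floor lies within the scatter). For compound 3 the estimated value is 80000 nM, with an expected range of 15000 nM to 200000 nM.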

Compound 3, half-maximal inhibitory concentration: 200 nM
Compound 3: middle estimate off by 400-fold (2.60 log units), on the high side, outside the stated range (below it).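

On an amide-type nitrogen, the earlier compounds had shown only that neither ethyl nor cyclohexyl gave a readable value: the limit of > 100000 nM in this assay, at which 2 of the 3 values shown sit.

Compound 3 shows that this position can respond strongly in this assay, with phenyl in place of cyclohexyl giving an at least 500-fold lower number from compound 2 to compound 3 (2.69 log units; beyond the scatter) and phenyl in place of ethyl giving an at least 500-fold lower number from compound 1 to compound 3 (2.69 log units; beyond the scatter). Cyclohexyl and phenyl both have six carbons in a six-membered ring, so the large step comes with the change from a non-aromatic to an aromatic ring, not with a change in heavy-atom count.

The compounds shown leave open whether a benzyl group or a pyridyl ring on this nitrogen would hold the gain. They also leave open how a methoxy or chloro group on the phenyl ring would alter it.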